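The source may hold more compounds than are shown below. What is called first, only, known or untested is meant among the compounds shown, and "the series" means these compounds.

Working notes on the series.

Compound 1 `Cn1c(=O)c(S(=O)(=O)c2ccc(F)cc2F)cc2cnc(Nc3ccc4cc[nH]c4c3)nc21` gives 5000 nM in a functional assay on K562 cells (Homo sapiens) for inhibition, read by trypan blue exclusion, with a stated time of 72 h; a higher number here means a weaker inhibitor, a lower number a stronger inhibitor. Compound 2 `Cn1c(=O)c(S(=O)(=O)c2ccc(F)cc2F)cc2cnc(Nc3ccc4cccc(O)c4n3)nc21` gives 5000 nM in this assay, and the step of no change at the digits printed from compound 1 to compound 2 (within the scatter) is flat. Compound 3 `Cn1c(=O)c(S(=O)(=O)c2ccc(Cl)cc2)cc2cnc(Nc3cnc4[nH]ccc4c3)nc21` gives 5000 nM in this assay and so stands level with compound 1 and compound 2 at the digits shown.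

Compound 4 `Cn1c(=O)c(S(=O)(=O)c2ccc(F)cc2F)cc2cnc(Nc3cnc4[nH]ccc4c3)nc21` carries the change (2,4-difluorophenyl in place of 4-chlorophenyl on a sulfonyl sulfur). Within the data shown here, no measured step covers this change on the sulfonyl sulfur; the only measured step concerns the nitrogen on the aromatic ring. Compound 1 and compound 2 already carry the 2,4-difluorophenyl on the sulfonyl sulfur and sit at the same level as compound 3, so compound 4 is expected to show no change at the digits printed from compound 3 to compound 4 (within the scatter), no step beyond the scatter. Compound 4 is therefore estimated at 5000 nM, within 2500 nM to 10000 nM.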

Compound 4, half-maximal inhibitory concentration: 750 nM
For compound 4 the middle estimate is 6.7-fold (0.82 log units) above the measured one; measured number outside the range, below it.
By their numbers in this assay, from the lowest: compound 4; then compounds 1, 2 and 3 (each within the scatter of the next).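

On the sulfonyl sulfur, 2,4-difluorophenyl in place of 4-chlorophenyl gives a 6.7-fold lower number from compound 3 to compound 4 (0.82 log units; beyond the scatter), so this position can move the number. The 2,4-difluorophenyl does not set the level alone: with it held constant, changing only the group on a nitrogen on an aromatic ring gives a 6.7-fold lower number from compound 2 to compound 4 (0.82 log units; beyond the scatter) and a 6.7-fold lower number from compound 1 to compound 4 (0.82 log units; beyond the scatter). The lower number thus appears only with this pairing of the two groups among the compounds shown.

No evidence on the cause of these steps is at hand. Still open, going by these compounds, is how an amine or a carboxylic acid on the phenyl ring on the sulfonyl sulfur would compare.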